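Weak cytotoxicity across a small series; butyl amide estimated

A few compounds are considered here, and "the series" means these few. Any claim that something is new, unique, unknown or untested is made for them only; others in the source may bear on it.

Measured so far:
compound 1, `CCOc1ccc(NC(=O)c2cccc(/C=C3\CC(=O)N(Cc4ccccc4)C3=O)c2)cc1`, 73200 nM
compound 2, `CCOc1ccc(NC(=O)c2cccc(/C=C3\CC(=O)N(c4ccccc4)C3=O)c2)cc1`, 91500 nM
compound 3, `COc1ccc(NC(=O)c2cccc(/C=C3\CC(=O)N(c4ccccc4)C3=O)c2)cc1`, a limit, > 100000 nM

All three were tested in an ADME assay on SW480 cells (Homo sapiens) for cytotoxicity, read by MTT assay, with a stated time of 72 h; a lower number here means a stronger inhibitor, a higher number a weaker inhibitor. Compound 1 gives 73200 nM and sits at one end of the two plain numbers; its nearest neighbour is compound 2, and the step of a 1.3-fold higher number from compound 1 to compound 2 (0.10 log units; within the scatter) is within the scatter. For compound 3 this assay reports only a limit, > 100000 nM. The series therefore contains (the limit of > 100000 nM in this assay, at which 1 of the 3 values shown sits). The step of an at least 1.0-fold higher number from compound 2 to compound 3 (0.03 log units; that floor lies within the scatter) likewise stays within the scatter.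

Compound 4, `CCCCNC(=O)c1cccc(/C=C2\CC(=O)N(Cc3ccccc3)C2=O)c1`, has not yet been measured. It differs from compound 1 by butyl in place of 4-ethoxyphenyl on an amide-type nitrogen. Going by the values given here, neither measured step touches this amide nitrogen, so they give no direct guide; they show only that the small changes made so far left the numbers essentially unchanged, all of them weak. Compound 4 is therefore expected to remain weak, with a step of a 1.2-fold higher number from compound 1 to compound 4 (0.09 log units; within the scatter) that need not exceed the scatter. The estimate for compound 4 is 90000 nM, within 40000 nM to 200000 nM.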

Compound 4, half-maximal inhibitory concentration: > 100000 nM
Compound 4 was reported as a limit; the forecaster's own chance of this, stated with the estimate: 40%; middle value at least 1.1-fold (0.04 log units) from the limit.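

This is the first change shown on this amide-type nitrogen, and it replaces the 4-ethoxyphenyl, which carries an aromatic ring, with a butyl chain that has no ring. In this assay compound 4 gives > 100000 nM, which is a limit and not a number. The step is an at least 1.3-fold higher number from compound 1 to compound 4 (0.13 log units; that floor lies within the scatter), so the aromatic ring can go from this position with no sign of a stronger inhibitor, but the true size of the step stays hidden, as the series now has two compounds at the ceiling: the limit of > 100000 nM in this assay, at which 2 of the 4 values shown sit.

The compounds shown do not tell how a carboxylic acid or an amine at the end of the butyl chain would read on this nitrogen. They also leave open whether butyl would read the same with phenyl in place of benzyl on the other amide-type nitrogen.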